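Adding a Nitrile to the Pyrazole: Expected Effect on Affinity

The source may hold more compounds than are shown below. What is called first, only, known or untested is meant among the compounds shown, and "the series" means these compounds.

Compound 1 `O=C(NCc1ccc(OCc2ccccc2)cc1)n1cccn1` and compound 2 `N#Cc1cnn(C(=O)NCc2ccc(OCc3ccccc3)cc2)c1` share one core, and compound 3 `O=C(N1CCCN(Cc2ccc(OCc3ccccc3)cc2)CC1)n1cccn1` and compound 4 `N#Cc1cnn(C(=O)N2CCCN(Cc3ccc(OCc4ccccc4)cc3)CC2)c1` share another. How the two cores differ is not broken down here. In an assay on membranes from brain for binding affinity to Fatty-acid amide hydrolase 1 (Mus musculus), read by fluorescence, with stated times of 1 h and 30 min (on this read-out lower numbers stand for stronger inhibition and higher numbers for weaker inhibition), compound 1 gives 800 nM. Compound 2 carries a cyano in place of hydrogen on an aromatic carbon and in this assay gives 60 nM, so the step of a 13-fold lower number from compound 1 to compound 2 (1.12 log units; beyond the scatter). Compound 3 in this assay gives 450 nM; against compound 1 this lies within the usual scatter of the measurement, while against compound 2 it lies well beyond it.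

Compound 4 is not yet measured. It differs from compound 3 by a (cyano in place of hydrogen on an aromatic carbon). The place of this change and the group that enters are described in the same words as for the step from compound 1 to compound 2, so it is the same change, seen a second time among these compounds, and it is the only such pair measured so far. Resting on compound 1 and compound 2, whose step was a 13-fold lower number from compound 1 to compound 2 (1.12 log units; beyond the scatter), the step of an 11-fold lower number from compound 3 to compound 4 (1.05 log units; beyond the scatter) is the expected outcome for compound 4. Because compound 3 gives 450 nM, compound 4 is estimated at 40 nM in this assay, with a plausible range from 15 nM to 120 nM, since one prior example cannot show whether the gain carries over fully to a different core.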

Compound 4, half-maximal inhibitory concentration: < 10 nM
Compound 4: a limit, no number (the forecaster's own chance of this, stated with the estimate: 2%); middle value at least 4.0-fold (0.60 log units) away from the limit.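

In this assay, going by these compounds alone, compound 4 gives < 10 nM, which is a limit of the assay and not a number, and it is the only value of this kind here: the limit of < 10 nM in this assay, at which 1 of the 4 values shown sits. Replacing 1H-pyrazol-1-yl with 4-cyano-1H-pyrazol-1-yl again strengthens inhibition, with an at least 45-fold lower number from compound 3 to compound 4 (1.65 log units; beyond the scatter), so the change works in the same direction on both cores, but its size does not stay the same: the same change on two cores in this assay, a 13-fold lower number (1.12 log units; beyond the scatter) from compound 1 to compound 2 and an at least 45-fold lower number (1.65 log units; beyond the scatter) from compound 3 to compound 4, at least 3.3-fold (0.52 log units) apart, beyond the scatter of two such steps. This shows that the gain from the nitrile carried over from one core to the other and was larger on the second, but it does not give the full size of that second step, and two cores offer no rule for how the change would behave on any further core.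

The compounds shown carry only hydrogen or cyano at this place on the ring, so it remains open whether another group there, such as a methyl group, a carboxylic acid or an amine, would bring a similar gain. It also remains open why the same change gives steps of different size on the two cores, since these four compounds show the size of the difference but not its origin.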